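The compounds below may be only part of what the source reports. "The series", "measured", "known", "first", "only" and "open" are said of these compounds alone.

In a functional assay on HL-60 cells (Homo sapiens) for cytotoxicity, read by MTT assay, with a stated time of 4 days (a higher number here means a weaker inhibitor, a lower number a stronger inhibitor), two compounds have been tested. Compound 1 (`Cc1ccc(S(=O)(=O)Oc2ccc3c(c2C)[C@H](Cn2cc(-c4ccccc4)nn2)[C@@]24CC(=O)[C@@](C)(CC[C@@H]32)C4)cc1`) gives > 20000 nM in this assay, which is a limit of the assay rather than a number. Compound 2 (`C=C1C[C@]23C[C@@]1(O)CC[C@@H]2c1cccc(C)c1[C@@H]3Cn1cc(-c2ccc(Br)cc2)nn1`) gives > 20000 nM in this assay, again a limit and not a number. Both sit at the same boundary, as the limit of > 20000 nM in this assay, at which 2 of the 2 values shown sit, records, and nothing shown separates compound 1 from compound 2. Compound 3 (`C=C1C[C@]23C[C@@]1(O)CC[C@@H]2c1cccc(C)c1[C@@H]3Cn1cc(-c2ccc(C)cc2)nn1`) has not yet been measured. It differs from compound 2 in one place: methyl in place of bromo on an aromatic carbon. No measured step of this kind exists among these compounds, so the size of the change cannot be read from them. The expected step, a step that the limit leaves unreadable from compound 2 to compound 3, is none beyond the usual scatter. This expectation rests on (the limit of > 20000 nM in this assay, at which 2 of the 2 values shown sit). Compound 3 is therefore estimated at 30000 nM, between 10000 nM and 100000 nM, most likely reported once more only as a limit.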

Compound 3, half-maximal inhibitory concentration: > 20000 nM
Compound 3 gave a limit, no number (the forecaster's own chance of this, stated with the estimate: 85%); the middle value does not contradict the limit.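

In this assay compound 3 gives > 20000 nM, a limit and not a number. Going by these compounds alone, compound 2 also stands at a limit, so no step from compound 2 to compound 3 can be read. The compounds shown leave open whether methyl in place of bromo changes the activity at all.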